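Triazine-bearing benzyloxy butenolides in a pancreatic cell assay

The source may hold more compounds than are shown below. What is called first, only, known or untested is meant among the compounds shown, and "the series" means these compounds.

Measured so far:
compound 1 `O=C1O/C(=C\Cn2ncc(=O)[nH]c2=O)C(OCc2ccccc2)=C1OCc1ccccc1` — 20400 nM
compound 2 `O=C1O[C@H]([C@@H](O)Cn2ccc(NC(=O)c3ccccc3)nc2=O)C(OCc2ccccc2)=C1OCc1ccccc1` — a limit only

In a functional assay on MIA PaCa-2 cells (Homo sapiens) for inhibition, read by MTT assay, with a stated time of 72 h (on this read-out lower numbers stand for stronger inhibition and higher numbers for weaker inhibition), compound 1 gives 20400 nM. Compound 2 yields no number in this assay, only > 100000 nM, which is a limit of the assay. Within the data shown here, compound 1 therefore stands as the one measured number here; the other entry is the limit of > 100000 nM in this assay, at which 1 of the 2 values shown sits. Among the measured compounds shown here, no pair of measured compounds differs in a single place, so no measured step is available to calibrate a change of the kind below.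

Compound 3 `O=C1O/C(=C\Cn2c(=O)[nH]c(=O)[nH]c2=O)C(OCc2ccccc2)=C1OCc1ccccc1` remains to be measured. It differs from compound 1 by a group of 9 heavy atoms (3 carbon, 3 nitrogen, 3 oxygen; one six-membered aromatic ring with 3 hetero atoms) in place of a group of 8 heavy atoms (3 carbon, 3 nitrogen, 2 oxygen; one six-membered aromatic ring with 3 hetero atoms), on a saturated chain carbon bound to a double-bonded chain carbon. For the measured compounds named here, with no measured step as a guide, the expected step from compound 1 to compound 3 in this assay is a 1.5-fold higher number from compound 1 to compound 3 (0.17 log units; within the scatter), a move toward weaker inhibition that is not expected to exceed the usual scatter. Compound 3 is accordingly estimated at 30000 nM, with a range from 8000 nM to 100000 nM.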

Compound 3, half-maximal inhibitory concentration: 37900 nM
Beside the measured number, compound 3's estimate is 1.3-fold (0.10 log units) below it; the measured number falls inside the stated range.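

In this assay, among these compounds, this is the first measured step at this position: on a saturated chain carbon bound to a double-bonded chain carbon, the group of 9 heavy atoms in place of the group of 8 heavy atoms gives a 1.9-fold higher number from compound 1 to compound 3 (0.27 log units; within the scatter) and so separates the two compounds by no more than the scatter. Within this pair, then, the extra oxygen, the third double bond outside the aromatic ring and the second hydrogen-bond donor come with no change that can be read. Nothing at hand bears on the cause of this small step.

The compounds shown leave open whether an amine or a carboxylic acid at this place, or a longer chain carrying the ring, would move the number beyond the scatter. Also open, on these data alone, is whether a ring without hetero atoms here would do so.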